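Halogen swap on the benzyl arm of a DU-145 series

The source may report more compounds than this note shows. Statements on the series, on what has been measured and on what is new or still open speak of the compounds shown alone.

Compound 1 `COc1ccc(/C=C2\CN(Cc3cn(Cc4cccc(Cl)c4)nn3)C/C(=C\c3ccc(OC)cc3)C2=O)cc1`: 15400 nM
Compound 2 `Cc1ccc(/C=C2\CN(Cc3cn(Cc4ccc(F)cc4)nn3)C/C(=C\c3ccc(C)cc3)C2=O)cc1`: 49700 nM
Compound 3 `Cc1ccc(/C=C2\CN(Cc3cn(Cc4cccc(Cl)c4)nn3)C/C(=C\c3ccc(C)cc3)C2=O)cc1`: 33100 nM

In a functional assay on DU-145 cells (Homo sapiens) for cytotoxicity, read by MTT assay, with a stated time of 24 h (a lower number here means a stronger inhibitor, a higher number a weaker inhibitor), compound 1 gives the lowest of the three numbers. Compound 3 sits next to it, and compound 2 gives the highest number. Compounds 2 and 3 share one core, compound 1 another; the difference between the two cores is not broken down here.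

Going from compound 3 to compound 2 the change is 4-fluorophenyl in place of 3-chlorophenyl on a saturated chain carbon bound to an aromatic nitrogen, and this gave a 1.5-fold higher number from compound 3 to compound 2 (0.18 log units; within the scatter). Compound 4 `COc1ccc(/C=C2\CN(Cc3cn(Cc4ccc(F)cc4)nn3)C/C(=C\c3ccc(OC)cc3)C2=O)cc1` is not yet measured; it arises from compound 1 by 4-fluorophenyl in place of 3-chlorophenyl on a saturated chain carbon bound to an aromatic nitrogen, the same change. Because a 1.5-fold higher number from compound 3 to compound 2 (0.18 log units; within the scatter) stayed within the scatter, a similar small step is expected here too, so that from compound 1 to compound 4 the estimated step is a 1.4-fold higher number from compound 1 to compound 4 (0.15 log units; within the scatter). For compound 4 in this assay the estimated value is 22000 nM, expected to lie between 10000 nM and 50000 nM.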

Compound 4, half-maximal inhibitory concentration: 59400 nM
Beside the measured number, compound 4's estimate is 2.7-fold (0.43 log units) below it; measured number above the stated range.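

In this assay, putting 4-fluorobenzyl in place of 3-chlorobenzyl gave a 3.9-fold higher number from compound 1 to compound 4 (0.59 log units; beyond the scatter). Set beside the earlier step, the two cores do not truly separate, since the gap between the two steps is no larger than repeated measurements can produce: the same change on two cores in this assay, a 1.5-fold higher number (0.18 log units; within the scatter) from compound 3 to compound 2 and a 3.9-fold higher number (0.59 log units; beyond the scatter) from compound 1 to compound 4, 2.6-fold (0.41 log units) apart, within the scatter of two such steps. The change therefore points the same way on both cores, but this does not show that the core of compound 1 responds more strongly, and two pairs make no general rule.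

Still open, as far as these compounds go, is whether the halogen or its place on the ring drives the step, which a 4-chlorobenzyl or 3-fluorobenzyl arm could separate. A plain benzyl arm could show what either halogen adds.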